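The source may hold more compounds than are shown below. What is called first, only, known or untested is meant among the compounds shown, and "the series" means these compounds.

In a functional assay on U-251 cells (Homo sapiens) for inhibition, read by sulforhodamine B assay, with a stated time of 72 h (on this read-out lower numbers stand for an effect already at smaller amounts and higher numbers for an effect only at larger amounts of compound), compound 1 `O=C(/C=C/c1ccc([N+](=O)[O-])o1)c1ccc(N2CCCCC2)cc1` gives > 50000 nM, which is a limit of the assay and not a number. Compound 2 `O=C(/C=C/c1ccc([N+](=O)[O-])s1)c1ccc(-n2ccnc2)cc1` gives 9400 nM. Compound 3 `O=C(/C=C/c1ccc(Cl)s1)c1ccc(-n2ccnc2)cc1` gives 35100 nM, the higher of the two actual numbers. Compound 4 `O=C(/C=C/c1ccc(Cl)s1)c1ccc(N2CCCCC2)cc1` has not yet been measured and differs from compound 3 in one place, with piperidin-1-yl in place of 1H-imidazol-1-yl on an aromatic carbon.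

Among the measured compounds shown here, no measured step covers this exchange. For the measured compounds named here, the only step available, a 3.7-fold higher number from compound 2 to compound 3 (0.57 log units; beyond the scatter), concerns a different place and bears on it only indirectly. Going by the values given here, the one measured compound carrying piperidin-1-yl is compound 1, which stands at the limit of > 50000 nM in this assay, at which 1 of the 3 values shown sits. Among the compounds with values here, on that basis, no step clearly beyond the scatter is expected in this assay, though the expectation leans toward a higher number, and the assay may report only a limit. The expected step is a 1.4-fold higher number from compound 3 to compound 4 (0.15 log units; within the scatter). For compound 4 the estimated value is 50000 nM, with an expected range of 20000 nM to 120000 nM.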

Compound 4, half-maximal effective concentration: > 50000 nM
Compound 4: no number, only a limit; the forecaster's own chance of this, stated with the estimate: 55%; the middle value lies on the limit itself.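

In this assay, the exchange of 1H-imidazol-1-yl for piperidin-1-yl on an aromatic carbon gives an at least 1.4-fold higher number from compound 3 to compound 4 (0.15 log units; that floor lies within the scatter), so only a floor for this change is known, and that floor does not show a real difference between the two groups. Compound 4 has no number, only a limit of the assay, and piperidin-1-yl has now met such a limit with 5-chlorothiophen-2-yl as well as with 5-nitrofuran-2-yl: the limit of > 50000 nM in this assay, at which 2 of the 4 values shown sit. The step between the two compounds carrying piperidin-1-yl cannot be read.

On these data alone, it remains open how far compound 4 truly lies from compound 3, and whether piperidin-1-yl would also reach the limit alongside the nitro group of compound 2. Also open, as far as these compounds go, is what a morpholin-4-yl or a dimethylamino group would give in this place.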